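The source may hold more compounds than are shown below. What is called first, only, known or untested is meant among the compounds shown, and "the series" means these compounds.

Measured compounds
- compound 2, `O=C(C1CC1)[C@H]1C[C@H]2CNC[C@H]2C1`: 120%
- compound 1, `COC(=O)N1CC2CNCC2C1`: "not determined" (no result reported)

Compound 1 `COC(=O)N1CC2CNCC2C1` carries a methoxycarbonyl group on a ring nitrogen of the shared core; for it no number was reported in an assay on SHEP1 cells for agonist activity at Neuronal acetylcholine receptor; alpha4/beta2 (Homo sapiens), read by FLIPR and calcium flux (a higher number here means a larger maximal response, a lower number a smaller maximal response), so it gives no foothold for comparison. For the measured compounds named here, compound 2 `O=C(C1CC1)[C@H]1C[C@H]2CNC[C@H]2C1` is therefore the only compound with a number: in this assay compound 2 gives 120%, a maximal response somewhat above the reference, and it stands alone as the single measured point.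

Compound 3 `COC(=O)[C@H]1C[C@H]2CNC[C@H]2C1` differs from compound 2 in one place: methoxy in place of cyclopropyl on a carbonyl carbon. The carbonyl stays on the saturated ring carbon; only the group on the other side of it changes, a cyclopropyl leaving and a methoxy entering.

Going by the values given here, no step between measured compounds is known, so the size of this change cannot be read from the series. Drawing on the single value of compound 2 in this assay, 120%, the expectation for the step is a moderate decrease in maximal response, expected as a number 20 percentage points lower from compound 2 to compound 3 (beyond the scatter), a shift judged to lie at the edge of or somewhat beyond the scatter rather than a large loss. Compound 3 is accordingly expected to reach 100% in this assay, with an estimated range from 70% to 130%.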

Compound 3, largest response reached (Emax), in percent of the reference or control that the assay uses: 130%
Estimate against measurement, compound 3: 30 percentage points below; the range from low to high includes it.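

In this assay, the series now has its first readable step at the carbonyl carbon: methoxy in place of cyclopropyl gives a number 10 percentage points higher from compound 2 to compound 3 (within the scatter), so compound 2 and compound 3 cannot be told apart on maximal response. For the compounds shown here, the exchange removes a three-membered ring of carbon only and adds a hydrogen-bond acceptor, yet this large a change in the group on the carbonyl carbon leaves no readable difference in this read-out, which the single value of compound 2 could not show. No measurement at hand explains why the two groups give matching responses.

As far as these compounds go, two groups on the carbonyl carbon say little about the position as a whole, and it remains open whether the same holds for an amine in place of the methoxy, for a carboxylic acid, or for a longer chain such as ethoxy or butyl. Steps involving compound 1 cannot be read, since compound 1 stands at "not determined" (no result reported), so the methoxycarbonyl group on a ring nitrogen offers no comparison with this series.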